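Lengthening a chain on an iminosugar guanidine

This account rests on a few compounds, and the source may have more. Where it says the series, first, only, none or still open, it means among the compounds named here.

Compound 1, `CCCCNC(=O)N1C[C@H](O)[C@@H](O)[C@H](O)[C@H]1CO`, opens the set. In an assay on isolated protein for inhibition of alpha-galactosidase (Coffea arabica), read by spectrophotometry, with a stated time of 30 min (on this read-out higher numbers stand for weaker inhibition and lower numbers for stronger inhibition), compound 1 gives > 1000000 nM, which is a limit of the assay rather than a number (the limit of > 1000000 nM in this assay, at which 1 of the 2 values shown sits). Compound 2, `CCCCNC(=N)N1C[C@H](O)[C@@H](O)[C@H](O)[C@H]1CO`, is its close relative. In this assay, going by the values given here, compound 2 gives 18000 nM, and this is the only actual number among the results so far. Compound 3, `CCCCCCCCNC(=N)N1C[C@H](O)[C@@H](O)[C@H](O)[C@H]1CO`, has not yet been tested. It differs from compound 2 by butyl in place of hydrogen on a saturated chain carbon, four bonds along the chain from an amine nitrogen. Among the compounds with values here, no step between two measured compounds is available to guide the expectation, so the estimate rests on compound 2 alone. The expected step of a 3.0-fold lower number from compound 2 to compound 3 (0.48 log units; beyond the scatter) is a modest gain in inhibition, somewhat beyond the scatter, but held with little confidence. Compound 3 is therefore estimated at 6000 nM, within a range from 1500 nM to 25000 nM.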

Compound 3, half-maximal inhibitory concentration: 23000 nM
Beside the measured number, compound 3's estimate is 3.8-fold (0.58 log units) below it; the range from low to high includes it.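

In this assay, the step at this position reads a 1.3-fold higher number from compound 2 to compound 3 (0.11 log units; within the scatter), so the two values cannot be told apart. Going by these compounds alone, this is the first readable step in the set, and it shows that butyl in place of hydrogen on a saturated chain carbon, four bonds along the chain from an amine nitrogen, leaves inhibition of the enzyme where it was, with neither a gain nor a loss that stands out from repeat measurements. Nothing available here bears on why this longer chain leaves the number unmoved.

A single step cannot show a trend with chain length, so a hexyl chain or a dodecyl chain might behave differently. A chain ending in an amine or a carboxylic acid also remains an open case.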